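Thioester in place of an alkynyl ester: expected lipophilicity

A few compounds are considered here, and "the series" means these few. Any claim that something is new, unique, unknown or untested is made for them only; others in the source may bear on it.

Measured compounds:
compound 1, `C#CCCOC(=O)/C=C(C)/C=C/CC(C)CCCC(C)(C)OC`, 5.2
compound 2, `CC(=O)OC(C)(C)CCCC(C)C/C=C/C(C)=C/C(=O)OC(C)C`, 5.98

In a physicochemical assay for lipophilicity (a higher number here means a more lipophilic compound, a lower number a more polar compound), compound 1 gives 5.2, the lower of the two numbers; compound 2 gives 5.98, a gap beyond the usual scatter. For the measured compounds named here, no single-change pair has been measured yet. Compound 3, `COC(C)(C)CCCC(C)C/C=C/C(C)=C/C(=O)SC(C)C`, is still to be measured in this assay. It differs from compound 1 in one place: isopropylsulfanyl in place of (but-3-yn-1-yl)oxy on a carbonyl carbon. Going by the values given here, with no measured step of this kind to lean on, an upward move beyond the scatter is expected from compound 1 to compound 3, estimated at a number 0.80 log units higher from compound 1 to compound 3 (beyond the scatter). Compound 3 is therefore expected at 6, within 5.4 to 6.6.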

Compound 3, partition coefficient: 7.19
For compound 3 the middle estimate is 1.19 log units below the measured one, and the stated range ends below it.
By their numbers in this assay, from the lowest: compound 1; then compound 2; then compound 3.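

In this assay, putting isopropylsulfanyl in place of (but-3-yn-1-yl)oxy on a carbonyl carbon gives a number 1.99 log units higher from compound 1 to compound 3 (beyond the scatter) and is the only single-change step shown at this position. It shows that the group on this carbonyl carbon can shift the number by a large amount, even though the hydrogen-bond donor and acceptor counts of the two groups match. On these data alone, the swap changes the linking atom and the chain together, so one step cannot say which part carries the shift, and how an amide or a carboxylic acid on this carbonyl carbon would compare remains open. Nothing at hand explains the size of the step.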